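The compounds below may be only part of what the source reports. "The series", "measured", "known", "first", "only" and "open" are said of these compounds alone.

Compound 3 `Nc1nc(N)c(-c2ccc(NCc3ccc([N+](=O)[O-])cc3)cc2)c(COCc2ccccc2)n1` stands lowest of the three numbers in a functional assay on CHOK cells for antagonist activity at growth hormone secretagogue receptor type 1 (Homo sapiens), read by calcium flux; on this read-out lower numbers stand for stronger inhibition and higher numbers for weaker inhibition: compound 3 gives 5.8 nM. Its nearest neighbour is compound 1 `CCc1nc(N)nc(N)c1-c1ccc(NCc2cc(F)c(S(C)(=O)=O)c(F)c2)cc1`, which in this assay gives 45 nM; compound 2 `CCc1nc(N)nc(N)c1-c1ccc(NCc2cc(F)c(S(=O)(=O)C(F)(F)F)c(F)c2)cc1` lies furthest away, and in this assay compound 2 gives 690 nM. Compound 4 `N#Cc1ccc(COc2ccc(-c3c(N)nc(N)nc3COCc3ccccc3)cc2)cc1` differs from compound 3 in one place: (4-cyanobenzyl)oxy in place of (4-nitrobenzyl)amino on an aromatic carbon. Among the measured compounds shown here, the only single-place step among the measured compounds, a 15-fold higher number from compound 1 to compound 2 (1.19 log units; beyond the scatter), concerns the sulfonyl sulfur of a different side chain and so does not bear directly on the exchange of (4-nitrobenzyl)amino for (4-cyanobenzyl)oxy; no measured pair shows that exchange, and its size cannot be read from the data. The swap keeps a six-membered aromatic ring of carbon only at that position, but both the link to the ring and the group at its far end change, which in the absence of any comparable step leaves an expectation of a moderate rise in the number, with wide uncertainty. Compound 4 is therefore expected to give 15 nM in this assay, with a range from 4 nM to 60 nM. That estimate means a step of a 2.6-fold higher number from compound 3 to compound 4 (0.41 log units; beyond the scatter) is expected, a weakening that is uncertain in size.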

Compound 4, half-maximal inhibitory concentration: 3610 nM
Compound 4: the middle estimate sits 240-fold (2.38 log units) below what was measured; measured number outside the range, above it.
By their numbers in this assay, from the lowest: compound 3; then compound 1; then compound 2; then compound 4.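

In this assay, replacing (4-nitrobenzyl)amino with (4-cyanobenzyl)oxy on an aromatic carbon para to a large group gives a 620-fold higher number from compound 3 to compound 4 (2.79 log units; beyond the scatter) and so shows that the number responds very strongly to what is placed at this position. The response appears even though both groups carry one six-membered aromatic ring of carbon only, so keeping that ring is not enough to hold the number near that of compound 3. The exchange also goes from 1 hydrogen-bond donor to 0 and changes the link and the far end of the group together, and nothing measured here explains the size of the step.

The compounds shown leave open how much of the step belongs to the link and how much to the far end of the group, a question that (4-cyanobenzyl)amino and (4-nitrobenzyl)oxy at the same position would separate. They also leave open whether the same exchange would have a similar effect on the core of compound 1, which carries an ethyl group where compound 3 has its benzyl ether side chain.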